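A few compounds are considered here, and "the series" means these few. Any claim that something is new, unique, unknown or untested is made for them only; others in the source may bear on it.

Measured in a functional assay on A549 cells (Homo sapiens) for inhibition, read by MTT assay, with a stated time of 24 h; on this read-out lower numbers stand for stronger inhibition of growth and higher numbers for weaker inhibition of growth:
- compound 1 `COc1ccc(C(=O)n2c(-c3cn(C)c4ccccc34)nc3ccccc32)cc1OC`: 3100 nM
- compound 2 `COc1cc(C(=O)n2c(-c3cn(C)c4ccccc34)nc3ccccc32)cc(OC)c1OC`: 2600 nM

Among the compounds with values here, compound 2 stands at 2600 nM and cannot be separated from the only other measured compound: a 1.2-fold lower number from compound 1 to compound 2 (0.08 log units; within the scatter).

The next compound is compound 3 `COc1cc(C(=O)n2c(-c3cn(C)c4ccc(Br)cc34)nc3ccccc32)cc(OC)c1OC`, with the change (bromo in place of hydrogen on an aromatic carbon). In words, this is bromo in place of hydrogen on an aromatic carbon, taking 1-methyl-1H-indol-3-yl to 5-bromo-1-methyl-1H-indol-3-yl.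

Within the data shown here, the one measured step, a 1.2-fold lower number from compound 1 to compound 2 (0.08 log units; within the scatter), is a methoxy in place of hydrogen at another place in the molecule. Among the measured compounds shown here, it bears on this change only weakly, and no measured step involves bromo. No direction can be drawn from the data, so no step beyond the scatter is expected in this assay. The expected step is a 1.2-fold lower number from compound 2 to compound 3 (0.07 log units; within the scatter), with a wide margin. Compound 3 is estimated at 2200 nM, with an expected range of 700 nM to 6000 nM.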

Compound 3, concentration for 50% growth inhibition: 3000 nM
Compound 3: the middle estimate sits 1.4-fold (0.13 log units) below what was measured; the range from low to high includes it.
By their numbers in this assay, from the lowest: compounds 2, 3 and 1 (each within the scatter of the next).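

In this assay, within the data shown here, the change from 1-methyl-1H-indol-3-yl to 5-bromo-1-methyl-1H-indol-3-yl gives a 1.2-fold higher number from compound 2 to compound 3 (0.06 log units; within the scatter) and is the first reading on this part of the molecule, the earlier step having concerned a methoxy elsewhere. A bromo on this aromatic carbon of the six-membered ring of carbon only therefore leaves the number indistinguishable from that of the hydrogen parent, so this position accepts one heavy atom without a readable change. No supporting measurement is available to explain this result.

Going by these compounds, whether an amine, a carboxylic acid or a longer chain on this aromatic carbon would give a step beyond the scatter remains open. Among these compounds, also open is whether any change to the shared core can separate compounds in this growth read-out, with no step so far beyond the scatter.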